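From nitrile to fluorine on the shared core

A few compounds are considered here, and "the series" means these few. Any claim that something is new, unique, unknown or untested is made for them only; others in the source may bear on it.

Compound 1 `CC(C)(C)C1CSC(c2ccc(C#N)cc2)SC1`: 4.38
Compound 2 `CC1(c2ccc(C#N)cc2)SCC(C(C)(C)C)CS1`: 4.9

In a physicochemical assay for lipophilicity (a higher number here means a more lipophilic compound, a lower number a more polar compound), compound 1 gives 4.38, the lower of the two numbers. Compound 2 gives 4.9. For the measured compounds named here, the only measured step is a number 0.52 log units higher from compound 1 to compound 2 (beyond the scatter), a methyl in place of hydrogen on a saturated ring carbon. Compound 3 `CC(C)(C)C1CSC(c2ccc(F)cc2)SC1` differs from compound 1 elsewhere: fluoro in place of cyano on an aromatic carbon. No measured step touches that position, so nothing shown bears on it directly. The change removes one hydrogen-bond acceptor and adds none; on that basis a modest rise is expected, a number 0.67 log units higher from compound 1 to compound 3 (beyond the scatter). Compound 3 is estimated at 5.05, with a range from 4.65 to 5.45.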

Compound 3, partition coefficient: 4.97
Compound 3: the middle estimate sits 0.08 log units above what was measured; measured number inside the range.
By their numbers in this assay, from the lowest: compound 1; then compounds 2 and 3 (each within the scatter of the next).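

For the compounds shown here, replacing the cyano with fluoro on the aromatic carbon para to a large group gives the first measured step at this position: in this assay, it is a number 0.59 log units higher from compound 1 to compound 3 (beyond the scatter). What sits at this position therefore shifts the number, not only the methyl on the saturated ring carbon. Nothing shown gives a reason for this rise. As far as these compounds go, how an amine, a carboxylic acid or a methoxy group at this position would compare remains open. So does whether the methyl step would stay the same with fluoro in place of cyano.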